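A few compounds are considered here, and "the series" means these few. Any claim that something is new, unique, unknown or untested is made for them only; others in the source may bear on it.

The measured compounds:
compound 1, `O=C1OC(c2ccc(Cl)cc2)=C/C1=C\c1ccccc1Cl`, 81.5%
compound 2, `O=C1OC(c2ccc(Cl)cc2)=C/C1=C\c1ccc(Cl)cc1`, 69.1%
compound 3, `O=C1OC(c2ccc(Cl)cc2)=C/C1=C\c1ccccc1[N+](=O)[O-]`, 18.5%

All three were tested in a functional assay on the whole organism (strain Wistar) for inhibition, with Rattus norvegicus as the target, with stated times of 30 min and 3 h, at a dose of 20 mg/kg by the oral route; on this read-out higher numbers stand for more inhibition at the one dose given (going by the name of the read-out) and lower numbers for less inhibition. Compound 1 and compound 2 are built from the same atoms joined differently; the difference between their cores is 4-chlorophenyl in place of 2-chlorophenyl on a double-bonded chain carbon bound to a double-bonded ring carbon, and this change gives a number 12.4 percentage points lower from compound 1 to compound 2 (beyond the scatter). Compound 2 thus stands second of the three, with compound 1 above it and compound 3 far below. From compound 1 to compound 3 the change is nitro in place of chloro on an aromatic carbon, and it gives a number 63 percentage points lower from compound 1 to compound 3 (beyond the scatter).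

Compound 4, `O=C1OC(c2ccc(Cl)cc2)=C/C1=C\c1ccc([N+](=O)[O-])cc1`, has not yet been measured in this assay. It differs from compound 2 by nitro in place of chloro on an aromatic carbon. This is the same kind of change as that from compound 1 to compound 3, though not the same: in compound 3 the nitro stands ortho to a large group, while in compound 4 it stands para to a large group. The exchange has so far been made once, and the step it made was large. Because a number 63 percentage points lower from compound 1 to compound 3 (beyond the scatter) shows what this exchange did on the same core, a large drop is expected for compound 4 as well, although the different surroundings leave the size uncertain. Compound 4 is therefore expected to give about 20% in this assay, most likely between 5% and 45%, an expected step of a number 49.1 percentage points lower from compound 2 to compound 4 (beyond the scatter).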

Compound 4, a percentage reported as inhibition, in the whole organism at one dose (the size of the read-out at that dose, not a potency): 36%
The estimate for compound 4 lay 16 percentage points below the measured number, and the stated range covers the measured number.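

In this assay, nitro in place of chloro gives a number 33.1 percentage points lower from compound 2 to compound 4 (beyond the scatter), so on both cores the exchange lowers the number by a large step, and the direction of the change carries over from one core to the other. The size does not carry over, as the two steps differ by more than the scatter allows: the same change on two cores in this assay, a number 63 percentage points lower (beyond the scatter) from compound 1 to compound 3 and a number 33.1 percentage points lower (beyond the scatter) from compound 2 to compound 4, 29.9 percentage points apart, beyond the scatter of two such steps

These two pairs show that a step measured on one core in this series cannot be transferred to the other at full size, but they do not show why the sizes differ, and two pairs give no rule for how large the step would be on any further core.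

The compounds shown carry only chloro or nitro on the aromatic ring where the exchange was made, so it remains open how an amine, a methoxy group or a carboxylic acid would read there. All four compounds also share the 4-chlorophenyl group, which leaves open what a different group in its place, such as an unsubstituted phenyl or a short alkyl chain, would do to the number.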